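Adding a Second Fluorine at the Same Place

The source may report more compounds than this note shows. Statements on the series, on what has been measured and on what is new or still open speak of the compounds shown alone.

In an assay on isolated protein for inhibition of protein deacetylase HDAC6 (Homo sapiens), read by fluorescence, with a stated time of 1 h, tested at 100 nM (on this read-out lower numbers stand for less inhibition and higher numbers for more inhibition at the one concentration tested (going by the name of the read-out)), compound 3 `O=C(/C=C/c1ccc(OCc2nc(C3CCN(Cc4cccc(F)c4)CC3)no2)cc1)NO` gives 73%, the second highest of the three numbers measured. Compound 1 `Cc1ccc(CN2CCC(c3noc(COc4ccc(/C=C/C(=O)NO)cc4)n3)CC2)cc1` gives 76% and compound 2 `O=C(/C=C/c1ccc(OCc2nc(C3CCN(Cc4ccccc4F)CC3)no2)cc1)NO` gives 68%, both within the scatter of compound 3. Compound 4 `O=C(/C=C/c1ccc(OCc2nc(C3CCN(Cc4ccc(F)cc4F)CC3)no2)cc1)NO` differs from compound 3 by 2,4-difluorophenyl in place of 3-fluorophenyl on a saturated chain carbon bound to an amine nitrogen in a ring. The three measured steps at the same place, a number 8 percentage points lower from compound 1 to compound 2 (within the scatter), a number 3 percentage points lower from compound 1 to compound 3 (within the scatter) and a number 5 percentage points higher from compound 2 to compound 3 (within the scatter), all stayed within the scatter, so exchanging one ring for another at this place has so far changed the read-out little. For compound 4 a step of a number 1 percentage points lower from compound 3 to compound 4 (within the scatter) in this assay is therefore expected, nothing beyond the scatter. Compound 4 is estimated at 72%, with a range from 60% to 82%.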

Compound 4, a percentage reported as inhibition, at one concentration (the size of the read-out at that concentration, not a potency): 74%
Beside the measured number, compound 4's estimate is 2 percentage points below it; the measured number falls inside the stated range.
By their numbers in this assay, from the lowest: compounds 2, 3, 4 and 1 (each within the scatter of the next).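

In this assay fluoro in place of hydrogen on an aromatic carbon gives a number 6 percentage points higher from compound 2 to compound 4 (within the scatter) and so offers the first direct test of a second fluorine on this ring. The 2,4-difluorophenyl group also gives a number 1 percentage points higher from compound 3 to compound 4 (within the scatter) and a number 2 percentage points lower from compound 1 to compound 4 (within the scatter) so two fluorines on this ring leave the read-out as unchanged as one fluorine or a methyl group did. No measured evidence here accounts for this result.

From the compounds shown here alone, whether a pyridine ring, a methoxy group or a trifluoromethyl group at this place would also stay within the scatter remains open. Also open, going by these compounds, is whether these compounds would stay this close at a different concentration.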